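The source may report more compounds than this note shows. Statements on the series, on what has been measured and on what is new or still open speak of the compounds shown alone.

Compound 1 `O=C([C@H]1CC[C@H](c2nnn[nH]2)CC1)N1CC[C@](c2ccc(C(F)(C(F)(F)F)C(F)(F)F)cc2)(S(=O)(=O)c2ccc(F)cc2)C1`: 100%
Compound 2 `CCC1(C(=O)N2CC[C@](c3ccc(C(F)(C(F)(F)F)C(F)(F)F)cc3)(S(=O)(=O)c3ccc(F)cc3)C2)CCS(=O)(=O)CC1`: 3%

In an ADME assay on microsomes from liver (Homo sapiens) for metabolic stability, with a stated time of 10 min (on this read-out higher numbers stand for a more stable compound and lower numbers for a less stable compound), compound 2 stands lowest of the two, at 3%. Compound 3 `O=C(N1CC[C@](c2ccc(C(F)(C(F)(F)F)C(F)(F)F)cc2)(S(=O)(=O)c2ccc(F)cc2)C1)C1(CO)CCS(=O)(=O)CC1` differs from it by hydroxy in place of methyl on a saturated chain carbon bound to a saturated ring carbon. Within the data shown here, only one measured step bears on this: a number 97 percentage points lower from compound 1 to compound 2 (beyond the scatter), a large step that exchanged the whole 4-ethyl-1,1-dioxothian-4-yl group, so it shows range, not direction, for this smaller change. Since compound 2 holds only 3%, little room remains downward, and a moderate rise is expected. The expected step is a number 27 percentage points higher from compound 2 to compound 3 (beyond the scatter). For compound 3 the estimated value is 30%, with an expected range of 5% to 70%.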

Compound 3, percent of the compound remaining: 75%
Compound 3: the middle estimate sits 45 percentage points below what was measured; measured number outside the range, above it.
By their numbers in this assay, from the lowest: compound 2; then compound 3; then compound 1.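

In this assay, the exchange of methyl for hydroxy on a saturated chain carbon bound to a saturated ring carbon gives a number 72 percentage points higher from compound 2 to compound 3 (beyond the scatter) on its own. A single atom at this place therefore recovers most of the range that the exchange of the whole group had spanned. The 4-(hydroxymethyl)-1,1-dioxothian-4-yl group still does not match 4-(1H-tetrazol-5-yl)cyclohexyl, with a number 25 percentage points lower from compound 1 to compound 3 (beyond the scatter) remaining, and no measurement offered here explains either step.

The compounds shown leave open whether the free hydroxy is required. A methoxymethyl group, an aminomethyl group or a carboxylic acid at this place could test that.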